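The source may report more compounds than this note shows. Statements on the series, on what has been measured and on what is new or still open speak of the compounds shown alone.

Compound 1 `COc1ccc(NC(=O)Nc2n[nH]c3ccccc23)cc1` and compound 2 `CCCCOc1ccc(NC(=O)n2nc(N)c3ccccc32)cc1` were both tested in a functional assay on UO-31 cells (Homo sapiens) for inhibition, read by sulforhodamine B assay, with a stated time of 48 h; a higher number here means a weaker inhibitor of growth, a lower number a stronger inhibitor of growth. For compound 1 the assay gives only a limit, > 100000 nM. Among the measured compounds shown here, compound 2 gives 17500 nM in this assay, the single number obtained among the two, the other value sitting at the limit of > 100000 nM in this assay, at which 1 of the 2 values shown sits. Compound 3 `Nc1nn(C(=O)Nc2ccc(Cc3ccccc3)cc2)c2ccccc12` has not yet been measured; it differs from compound 2 by benzyl in place of butoxy on an aromatic carbon. For the measured compounds named here, no step between two measured compounds is known here, so the step expected from putting benzyl in place of butoxy is a 1.2-fold lower number from compound 2 to compound 3 (0.07 log units; within the scatter), a change not beyond the usual scatter in either direction. Compound 3 is therefore estimated at 15000 nM in this assay, with a range from 4000 nM to 60000 nM.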

Compound 3, concentration for 50% growth inhibition: 347 nM
The estimate for compound 3 lay 43-fold (1.64 log units) above the measured number; the measured number lies below the stated range.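

In this assay, the step of a 50-fold lower number from compound 2 to compound 3 (1.70 log units; beyond the scatter) shows that the aromatic carbon para to a large group is sensitive to what it carries. Benzyl, which brings a six-membered aromatic ring of carbon only and no oxygen, moves the number well beyond the scatter, whereas the earlier compounds offered no step at all. Steps to compound 1 cannot be read, since its value is only a limit: the limit of > 100000 nM in this assay, at which 1 of the 3 values shown sits.

The compounds shown leave open whether the aromatic ring or the loss of the ether oxygen matters more; a phenoxy or cyclohexylmethyl group on the same carbon would separate the two.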